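The source may hold more compounds than are shown below. What is called first, only, known or untested is meant among the compounds shown, and "the series" means these compounds.

Measured compounds:
Compound 1, `CC(C)c1nc(N)c2nn(-c3ccccc3)cc2n1`, gives 11%.
Compound 2, `Nc1nc(Cc2cccc(C(F)(F)F)c2)nc2cn(-c3ccccc3)nc12`, gives 41%.

Both compounds were tested in an assay on CHO cells for displacement of a labelled ligand from adenosine receptor A3 (Homo sapiens), read by scintillation counting, tested at 1 uM; a lower number here means less inhibition, a higher number more inhibition at the concentration tested (going by the name of the read-out). Among these two numbers compound 1 stands lowest; its only neighbour, compound 2, lies higher by more than the usual scatter, so the two values are told apart.

Compound 3, `Nc1nc(Cc2ccccc2Cl)nc2cn(-c3ccccc3)nc12`, has not yet been measured. It differs from compound 1 in one place: 2-chlorobenzyl in place of isopropyl on an aromatic carbon. Among the compounds with values here, the entering group carries a benzyl much like the one in compound 2, which gives 41% in this assay, whereas compound 1 with its isopropyl gives 11%.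

On that basis the step is expected to go upward and beyond the scatter, about a number 24 percentage points higher from compound 1 to compound 3 (beyond the scatter). Compound 3 is accordingly estimated to reach 35%, with a likely range from 15% to 58%.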

Compound 3, a percentage reported as inhibition, at one concentration (the size of the read-out at that concentration, not a potency): 22%
Compound 3: middle estimate off by 13 percentage points, on the high side, and the stated range covers the measured number.
By their numbers in this assay, from the lowest: compound 1; then compound 3; then compound 2.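

Putting 2-chlorobenzyl in place of isopropyl on the carbon between two ring nitrogen atoms gives a number 11 percentage points higher from compound 1 to compound 3 (beyond the scatter) in this assay and so shows that this position accepts a larger group with an aromatic ring, with a modest gain. A benzyl group alone does not fix the level reached, since compound 3 gives 22% and compound 2 gives 41% with a different benzyl group at this same carbon. Nothing measured here accounts for the rise.

Going by these compounds, how a plain benzyl without chlorine, or a benzyl with its chlorine elsewhere on the ring, would compare remains open. So does the outcome with a cyclohexyl or an amine at this carbon.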